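From 2-chlorobenzyl to 4-chlorobenzyl: a small step expected

The compounds below may be only part of what the source reports. "The series", "measured", "known", "first", "only" and "open" are said of these compounds alone.

Values in a functional assay on a cell-free system (plasma, Oryctolagus cuniculus) for inhibition, with stated times of 5 min, 1 min and 6 min; a higher number here means a weaker inhibitor, a lower number a stronger inhibitor:
- compound 1 `CCOC(=O)c1c(C)nc(-c2cccc(C#N)c2)n1OCC(N)=O`: > 30000 nM (a limit of the assay, not a number)
- compound 2 `CCOC(=O)c1c(C)nc(-c2cccc(C#N)c2)n1OCc1cccc(F)c1`: 22400 nM
- compound 3 `CCOC(=O)c1c(C)nc(-c2cccc(C#N)c2)n1OCc1ccccc1Cl`: 8710 nM

Of the two actual numbers in this assay, the lower belongs to compound 3, while the nearer comparison, compound 2, gives 22400 nM. Compound 4 `CCOC(=O)c1c(C)nc(-c2cccc(C#N)c2)n1OCc1ccc(Cl)cc1` has 4-chlorophenyl in place of 2-chlorophenyl on a saturated chain carbon bound to an oxygen on an aromatic ring.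

Among the measured compounds shown here, no measured step makes this exchange. The nearest guide is a 2.6-fold lower number from compound 2 to compound 3 (0.41 log units; beyond the scatter), a modest change between two other aryl groups at the same place. The two steps that replace carbamoyl, an at least 1.3-fold lower number from compound 1 to compound 2 (0.12 log units; that floor lies within the scatter) and an at least 3.4-fold lower number from compound 1 to compound 3 (0.53 log units; beyond the scatter), rest on the limit of > 30000 nM in this assay, at which 1 of the 3 values shown sits, and give floors only. With a 2.6-fold lower number from compound 2 to compound 3 (0.41 log units; beyond the scatter) as the guide, no change beyond the scatter is expected, although one of that size cannot be excluded.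

The expected step is a 1.3-fold higher number from compound 3 to compound 4 (0.10 log units; within the scatter). For compound 4 the estimated value is 11000 nM, with an expected range from 4000 nM to 26000 nM.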

Compound 4, half-maximal inhibitory concentration: 6830 nM
Beside the measured number, compound 4's estimate is 1.6-fold (0.21 log units) above it; measured number inside the range.
By their numbers in this assay, from the lowest: compounds 4 and 3 (each within the scatter of the next); then compound 2. At a limit, above all of these: compound 1.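

In this assay, exchanging 2-chlorobenzyl for 4-chlorobenzyl gives a 1.3-fold lower number from compound 3 to compound 4 (0.11 log units; within the scatter), so for this pair the site of the chlorine on the ring makes no difference that can be told from the scatter. The 3-fluorophenyl group is a different matter: a 3.3-fold lower number from compound 2 to compound 4 (0.52 log units; beyond the scatter) agrees with the earlier step to compound 3 and places both chlorophenyl compounds on the same side of compound 2. Compound 1 stands at a limit rather than a number, so an at least 4.3-fold lower number from compound 1 to compound 4 (0.64 log units; beyond the scatter) is a floor only: the limit of > 30000 nM in this assay, at which 1 of the 4 values shown sits.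

Compound 2 differs from compound 3 and compound 4 in both the halogen and where it sits, and the two changes remain unseparated. From the compounds shown here alone, whether 3-chlorophenyl, 4-methoxyphenyl or a longer chain such as 2-phenylethyl at this place would hold or shift the number also stays open.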